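A Second Chloro Substituent and Its Expected Effect

The source may hold more compounds than are shown below. What is called first, only, known or untested is meant among the compounds shown, and "the series" means these compounds.

Three compounds sharing a fused two-ring core carrying a chloromethyl-substituted benzyl group were measured in a functional assay on U-251 cells (Homo sapiens) for cytotoxicity, read by sulforhodamine B assay, with a stated time of 48 h; on this read-out lower numbers stand for stronger inhibition of growth and higher numbers for weaker inhibition of growth. Compound 1, `ClCc1ccccc1Cn1cnc2c(Cl)nc(Cl)nc21`, gives 310 nM. Compound 2, `ClCc1ccccc1Cn1cnc2c(Cl)ncnc21`, gives 2630 nM. Compound 3, `ClCc1cccc(Cn2cnc3ncnc(Cl)c32)c1`, gives 1940 nM. Compound 2 and compound 3 are built from the same atoms joined differently, and the difference between the two cores is not broken down here; their two values lie within the usual scatter of each other, so no order can be drawn from them.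

Compound 1 differs from compound 2 by chloro in place of hydrogen on an aromatic carbon. That single change gave an 8.5-fold lower number from compound 2 to compound 1 (0.93 log units; beyond the scatter), a step that lies beyond the scatter.

Compound 4, `ClCc1cccc(Cn2cnc3nc(Cl)nc(Cl)c32)c1`, has not yet been measured in this assay. It differs from compound 3 by chloro in place of hydrogen on an aromatic carbon. Among the measured compounds shown here, this is the same change as the one from compound 2 to compound 1, made at a place described in the same words, but on the core of compound 3 rather than the core of compound 2. Because the earlier change gave an 8.5-fold lower number from compound 2 to compound 1 (0.93 log units; beyond the scatter), compound 4 is expected to show a step of about a 6.9-fold lower number from compound 3 to compound 4 (0.84 log units; beyond the scatter) in this assay. On that basis compound 4 is estimated at 280 nM, with a likely range from 110 nM to 750 nM.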

Compound 4, concentration for 50% growth inhibition: 1380 nM
Compound 4: middle estimate off by 4.9-fold (0.69 log units), on the low side; measured number above the stated range.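

Placed on the aromatic carbon between two ring nitrogen atoms on the core of compound 3, chloro in place of hydrogen gave in this assay a 1.4-fold lower number from compound 3 to compound 4 (0.15 log units; within the scatter), so that pair cannot be put in any order. The same change therefore did not carry its earlier size over from one core to the other: the same change on two cores in this assay, an 8.5-fold lower number (0.93 log units; beyond the scatter) from compound 2 to compound 1 and a 1.4-fold lower number (0.15 log units; within the scatter) from compound 3 to compound 4, 6.0-fold (0.78 log units) apart, beyond the scatter of two such steps What this shows is limited to two pairs in a single cell assay: the size of this step depended on the core that received it, and a result from one of these cores was a poor guide to the other, but the data do not show what in the two cores produces the gap, nor which of the two steps a further core would resemble.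

The compounds shown carry only hydrogen or chloro at this carbon, so it remains open how an amine or a methoxy group there would behave on either core. From the compounds shown here alone, it also remains open whether replacing the chloromethyl group with a longer chain would change the gap between the two steps.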